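The compounds below may be only part of what the source reports. "The series", "measured", "known", "first", "only" and "open" are said of these compounds alone.

Measured so far in an assay on isolated protein for inhibition of tyrosine-protein phosphatase non-receptor type 13 (Homo sapiens), read by spectrophotometry; a higher number here means a weaker inhibitor, a lower number a stronger inhibitor:
compound 1, `CCCNC(=O)COc1ccc2cc(C(O)(C(F)(F)F)C(F)(F)F)c(O)cc2c1`, giving > 20000 nM;
compound 2, `O=C(COc1ccc2cc(C(O)(C(F)(F)F)C(F)(F)F)c(O)cc2c1)N(c1ccccc1)c1ccccc1`, giving 12400 nM.

Compound 1 stands at the edge of what this assay reports: its value is a limit and not a number (the limit of > 20000 nM in this assay, at which 1 of the 2 values shown sits). Compound 2, which carries two phenyl groups on the amide nitrogen in place of the propyl chain of compound 1, gives a measured number in this assay, though a weak one. Compound 3, `O=C(COc1ccc2cc(C(O)(C(F)(F)F)C(F)(F)F)c(O)cc2c1)NC1CC1`, differs from compound 1 only by cyclopropyl in place of propyl on an amide-type nitrogen. No step between measured compounds is shown, so nothing here tells how this assay answers such a change. Given that compound 1 itself is a limit, the step is expected to be small, none beyond the usual scatter, as the estimated step that the limit leaves unreadable from compound 1 to compound 3 expresses. Compound 3 is therefore expected to give about 25000 nM in this assay, within a range from 8000 nM to 80000 nM, with a fair chance that only a limit is reported.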

Compound 3, half-maximal inhibitory concentration: > 20000 nM
Compound 3: no number, only a limit (the forecaster's own chance of this, stated with the estimate: 60%); the middle value does not contradict the limit.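

Compound 1 and compound 3 both give only a limit and not a number, so no step from one to the other can be read: the limit of > 20000 nM in this assay, at which 2 of the 3 values shown sit.

The compounds shown leave open whether cyclopropyl in place of propyl on an amide-type nitrogen changes the result in this assay at all.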